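A few compounds are considered here, and "the series" means these few. Any claim that something is new, unique, unknown or untested is made for them only; others in the source may bear on it.

- Compound 1 `NC(=O)c1cc(-c2ccnc(N)n2)[nH]c1-c1cc(C(F)(F)F)ccc1Cl`: 2.3 h
- Compound 2 `CCc1ccc(Cl)cc1-c1[nH]c(-c2ccnc(N)n2)cc1C(N)=O`: 0.8 h

In an ADME assay on the whole organism (strain Balb) for metabolic stability, with Mus musculus as the target, at a dose of 10 mg/kg by the oral route (on this read-out higher numbers stand for a longer-lived compound and lower numbers for a shorter-lived compound), compound 2 has the lower of the two numbers, at 0.8 h, and the gap up to compound 1 lies beyond the scatter. Compound 3 `CCc1ccc(C(F)(F)F)cc1-c1[nH]c(-c2ccnc(N)n2)cc1C(N)=O` carries trifluoromethyl in place of chloro on an aromatic carbon, para to an ethyl group: trifluoromethyl in place of chloro on an aromatic carbon. Going by the values given here, no measured pair shows this change alone. Among the compounds with values here, the only hint is that compound 1, which also carries trifluoromethyl, gives 2.3 h. A small rise in this assay is therefore expected, perhaps none beyond the scatter, and the estimated step is a 1.5-fold higher number from compound 2 to compound 3 (0.18 log units; within the scatter). Compound 3 is estimated at 1.2 h, within a range of 0.5 h to 3 h.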

Compound 3, half-life: 1.8 h
Compound 3: the middle estimate sits 1.5-fold (0.18 log units) below what was measured, within the range that was stated.
By their numbers in this assay, from the lowest: compound 2; then compounds 3 and 1 (each within the scatter of the next).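

In this assay, going by these compounds alone, trifluoromethyl in place of chloro on an aromatic carbon, para to an ethyl group, gives a 2.3-fold higher number from compound 2 to compound 3 (0.35 log units; beyond the scatter) and so provides the first direct reading of this change, a modest one. Ethyl in place of chloro on an aromatic carbon, with trifluoromethyl kept, gives a 1.3-fold lower number from compound 1 to compound 3 (0.11 log units; within the scatter) and so shows no readable difference between those two compounds. On these data alone, how a nitrile, a methoxy group or an amine on the same carbon would compare remains open. Nothing available explains either step.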